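The source may hold more compounds than are shown below. What is called first, only, known or untested is meant among the compounds shown, and "the series" means these compounds.

Two members of the series have been measured in a functional assay on MCF7 cells (Homo sapiens) for cytotoxicity, read by MTT assay, with a stated time of 72 h; a higher number here means a weaker inhibitor, a lower number a stronger inhibitor. Compound 1 `CCNC(=O)N1CCN(C(=S)SCc2cn(Cc3ccccc3F)nn2)CC1` gives 5760 nM. Compound 2 `CCNC(=O)N1CCN(C(=S)SCc2cn(Cc3cc(OC)c(OC)c(OC)c3)nn2)CC1` reaches only a limit of the assay, > 128000 nM, which is the limit of > 128000 nM in this assay, at which 1 of the 2 values shown sits. Where compound 2 stands on the numbers shown is therefore known only as a limit, with no number beneath it. Compound 3 `CCN(C)C(=O)N1CCN(C(=S)SCc2cn(Cc3cc(OC)c(OC)c(OC)c3)nn2)CC1` has not been measured; it differs from compound 2 by methyl in place of hydrogen on an amide-type nitrogen. Going by the values given here, no measured pair shows this change, so its size in this assay cannot be read from the series. Because compound 2 reached only the limit (the limit of > 128000 nM in this assay, at which 1 of the 2 values shown sits), the expected step that the limit leaves unreadable from compound 2 to compound 3 is taken as none beyond the scatter, with compound 3 expected to sit at or past the same limit. The estimate for compound 3 is 150000 nM, with a range from 40000 nM to 500000 nM.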

Compound 3, half-maximal inhibitory concentration: 68500 nM
The estimate for compound 3 lay 2.2-fold (0.34 log units) above the measured number, within the range that was stated.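

Methyl in place of hydrogen on the amide-type nitrogen, whose other neighbours are the carbonyl carbon and a saturated chain carbon, now has a first reading in this assay, as ethylcarbamoyl becomes ethyl(methyl)carbamoyl: an at least 1.8-fold lower number from compound 2 to compound 3 (0.27 log units; that floor lies within the scatter). Going by these compounds alone, compound 3 gives 68500 nM, the first number for the substituent it shares with compound 2. The step remains only a floor, and it does not establish a change beyond the scatter, because compound 2 is known only as a limit: the limit of > 128000 nM in this assay, at which 1 of the 3 values shown sits.

On these data alone, whether a longer chain or a cyclopropyl group on this nitrogen would give a number that differs from compound 3 remains open. Also open, as far as these compounds go, is how the same methyl change behaves with the substituent of compound 1, which gives 5760 nM.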